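Chlorine in place of methyl on the amide ring

A few compounds are considered here, and "the series" means these few. Any claim that something is new, unique, unknown or untested is made for them only; others in the source may bear on it.

Measured so far:
compound 1 `CCN1CCN(c2cc(C)c3cc(NC(=O)c4cccc(C)c4)ccc3n2)CC1` — 13700 nM
compound 2 `CCN(CC)c1cc(C)c2cc(NC(=O)c3ccc(Cl)c(Cl)c3)ccc2n1` — 41200 nM
compound 3 `Cc1cc(N(C)C)nc2ccc(NC(=O)c3ccc(Cl)c(Cl)c3)cc12` — a limit of the assay, > 50000 nM

Of the compounds shown here, three have been measured in a functional assay on SK-BR-3 cells (Homo sapiens) for antiproliferative activity, read by MTT assay, with a stated time of 72 h; a lower number here means a stronger inhibitor, a higher number a weaker inhibitor. Compound 1 gives 13700 nM, and compound 2 gives 41200 nM. Compound 3 reaches only the limit of the assay, > 50000 nM. Among the two numbers shown, compound 1 stands lowest, and its nearest neighbour is compound 2, a gap that lies beyond the usual scatter. Among the measured compounds shown here, the one step between measured compounds that differ in a single place runs an at least 1.2-fold higher number from compound 2 to compound 3 (0.08 log units; that floor lies within the scatter); as one of its values sits at the limit of > 50000 nM in this assay, at which 1 of the 3 values shown sits, that step is only a floor.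

Compound 4 `CCN1CCN(c2cc(C)c3cc(NC(=O)c4ccc(Cl)cc4)ccc3n2)CC1` differs from compound 1 in one place: 4-chlorophenyl in place of 3-methylphenyl on a carbonyl carbon. For the measured compounds named here, no measured step touches this change, since compounds 2 and 3 carry a different aryl group on the carbonyl carbon and differ from each other elsewhere. With nothing to lean on, no step beyond the scatter is expected in either direction in this assay, and the estimate for compound 4 is therefore placed near compound 1. Compound 4 is expected to give 14000 nM, within a range of 5000 nM to 40000 nM. The estimated step of a 1.0-fold higher number from compound 1 to compound 4 (0.01 log units; within the scatter) is expected to stay within the scatter.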

Compound 4, half-maximal inhibitory concentration: 3020 nM
Estimate against measurement, compound 4: 4.6-fold (0.67 log units) above; the measured number lies below the stated range.
By their numbers in this assay, from the lowest: compound 4; then compound 1; then compound 2. At a limit, above all of these: compound 3.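

In this assay, the aryl group on the carbonyl carbon proves to be a place that responds to change: 4-chlorophenyl in place of 3-methylphenyl, with the rest of compound 1 held fixed, gives a 4.5-fold lower number from compound 1 to compound 4 (0.66 log units; beyond the scatter). Among the compounds shown here, the only earlier step concerned the amine substituent, and it could be read only as a floor within the scatter, so this is the first single change whose size clearly exceeds the scatter. Nothing measured here says what lies behind this step.

The change replaces the substituent and moves it in a single step, so the compounds shown leave open whether the chlorine itself or its place on the ring accounts for the lower number, a question that 3-chlorophenyl or 4-methylphenyl on the same carbonyl carbon would help to settle. Also open, from the compounds shown here alone, is how far the trend extends to other groups at this place, such as 4-fluorophenyl, 4-methoxyphenyl or unsubstituted phenyl, and whether 4-chlorophenyl gives a similar step when diethylamino stands on the core.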